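A few compounds are considered here, and "the series" means these few. Any claim that something is new, unique, unknown or untested is made for them only; others in the source may bear on it.

Compound 3 `NCc1ccc(C(=O)Nc2ccncc2F)cc1-c1cccc(C(=O)Nc2ccc(CC(=O)O)cc2)c1` stands at the long-lived end of an ADME assay on a cell-free system (plasma, Homo sapiens) for metabolic stability, read by LC-MS (on this read-out lower numbers stand for a shorter-lived compound and higher numbers for a longer-lived compound), with > 2 h as a limit, not a number. Compound 2 `NCc1ccc(C(=O)Nc2ccncc2F)cc1-c1cccc(C(=O)Nc2cccc(CC(=O)O)c2)c1` sits at that same limit with > 2 h as its reading. Compound 1 `CCCCOC(=O)c1cccc(NC(=O)c2cccc(-c3cc(C(=O)Nc4ccncc4F)ccc3CN)c2)c1` gives < 0.0834 h as a limit of its own at the short-lived end. Going to compound 4 `CC(C)OC(=O)c1cccc(NC(=O)c2cccc(-c3cc(C(=O)Nc4ccncc4F)ccc3CN)c2)c1` puts 3-(isopropoxycarbonyl)phenyl in place of 4-(carboxymethyl)phenyl on an amide-type nitrogen, a change counted as 3-(isopropoxycarbonyl)phenyl in place of 4-(carboxymethyl)phenyl on an amide-type nitrogen in the structures. The nearest guide is compound 1 with its butoxycarbonyl group, since an at least 23-fold higher number from compound 1 to compound 2 (1.37 log units; beyond the scatter) is a large step, while a step that the two limits leave unreadable from compound 2 to compound 3 cannot be sized. A large drop is expected in this assay with this reverse kind of change, and the estimated step is an at least 16-fold lower number from compound 3 to compound 4 (1.22 log units; beyond the scatter) as a result. Compound 4 is estimated at 0.12 h with 0.04 h to 0.6 h as its expected range.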

Compound 4, half-life: 0.567 h
Compound 4: the middle estimate sits 4.7-fold (0.67 log units) below what was measured; low and high end bracket the measured number.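

In this assay, isopropoxycarbonyl in place of carboxymethyl gives an at least 3.5-fold lower number from compound 2 to compound 4 (0.54 log units; beyond the scatter), and moving from the 4-(carboxymethyl)phenyl compound gives an at least 3.5-fold lower number from compound 3 to compound 4 (0.54 log units; beyond the scatter), so the ester is shorter-lived than either acid. Yet the ester's own alkyl group also counts: isopropyl in place of butyl gives an at least 6.7-fold higher number from compound 1 to compound 4 (0.83 log units; beyond the scatter). An ester at this place can therefore keep a readable half-life rather than falling to the short-lived limit.

Going by these compounds, it remains open whether a tert-butyl ester or a primary amide would last longer than the isopropyl ester. On these data alone, the true half-lives of the two acids also stay unknown.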